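Piperazine nitrogen substituent series: aryl versus cyclohexyl

The source may hold more compounds than are shown below. What is called first, only, known or untested is meant among the compounds shown, and "the series" means these compounds.

Measured compounds in a functional assay on HEK293 cells for agonist activity at Free fatty acid receptor 1 (Homo sapiens), read by fluorescence and calcium flux; on this read-out lower numbers stand for an effect already at smaller amounts and higher numbers for an effect only at larger amounts of compound:
- compound 1 `CC#CC(CC(=O)O)c1ccc(OCc2ccc(C(=O)N3CCN(Cc4ccccc4)CC3)s2)cc1`: 155 nM
- compound 2 `CC#CC(CC(=O)O)c1ccc(OCc2ccc(C(=O)N3CCN(C4CCCCC4)CC3)s2)cc1`: 820 nM
- compound 3 `CC#CC(CC(=O)O)c1ccc(OCc2ccc(C(=O)N3CCN(c4ccccc4F)CC3)s2)cc1`: 113 nM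

Compound 2 gives the highest number of the three. The step of a 5.3-fold higher number from compound 1 to compound 2 (0.72 log units; beyond the scatter) and the step of a 7.3-fold lower number from compound 2 to compound 3 (0.86 log units; beyond the scatter) are both beyond the scatter, while a 1.4-fold lower number from compound 1 to compound 3 (0.14 log units; within the scatter) is within it. Compound 4 `CC#CC(CC(=O)O)c1ccc(OCc2ccc(C(=O)N3CCN(c4ccccc4[N+](=O)[O-])CC3)s2)cc1` differs from compound 2 by 2-nitrophenyl in place of cyclohexyl on an amine nitrogen in a ring. The step that bears most directly on this is a 7.3-fold lower number from compound 2 to compound 3 (0.86 log units; beyond the scatter), where an aromatic ring likewise replaced the cyclohexyl on the ring nitrogen. A comparable drop in the number is therefore expected, as an estimated step of a 5.1-fold lower number from compound 2 to compound 4 (0.71 log units; beyond the scatter). Compound 4 is accordingly expected to give about 160 nM in this assay, with a range from 50 nM to 500 nM.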

Compound 4, half-maximal effective concentration: 94 nM
Estimate against measurement, compound 4: 1.7-fold (0.23 log units) above, and the stated range covers the measured number.
By their numbers in this assay, from the lowest: compounds 4, 3 and 1 (each within the scatter of the next); then compound 2.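

In this assay, a second aromatic ring on this amine nitrogen gives an 8.7-fold lower number from compound 2 to compound 4 (0.94 log units; beyond the scatter), so the gap from cyclohexyl is not confined to the 2-fluorophenyl case. With nitro in place of fluoro the result is a 1.2-fold lower number from compound 3 to compound 4 (0.08 log units; within the scatter), and with 2-nitrophenyl in place of benzyl it is a 1.6-fold lower number from compound 1 to compound 4 (0.22 log units; within the scatter), so benzyl, 2-fluorophenyl and 2-nitrophenyl are not told apart here, and only cyclohexyl stands off from them. No supporting data bear on why these groups compare as they do.

Open, from the compounds shown here alone, is how unsubstituted phenyl compares with these groups. Also open, going by these compounds, is whether a longer chain, such as phenethyl, keeps the number in the same range.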